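The source may report more compounds than this note shows. Statements on the series, on what has been measured and on what is new or still open speak of the compounds shown alone.

Of the compounds shown here, two with the same core have been measured so far in a functional assay on MDA-MB-231 cells (Homo sapiens) for antiproliferative activity, read by MTT assay, with a stated time of 24 h; a lower number here means a stronger inhibitor, a higher number a weaker inhibitor. Compound 1 `O=C(NNc1cccc(Cl)c1)c1ccc(NS(=O)(=O)c2cnc(O)nc2O)cc1` gives 17400 nM, and compound 2 `CCCCOc1ccc(C(=O)NNC(=O)c2ccc(NS(=O)(=O)c3cnc(O)nc3O)cc2)cc1` gives 11900 nM. These two values lie within the usual scatter of each other, so neither can be ranked ahead of the other. Compound 3 `Cc1ccccc1C(=O)NNC(=O)c1ccc(NS(=O)(=O)c2cnc(O)nc2O)cc1` has not yet been measured. It keeps the core of compound 2 but carries 2-methylphenyl in place of 4-butoxyphenyl on a carbonyl carbon. For the measured compounds named here, no measured pair differs in one place only, so this change has no direct precedent. Going by the values given here, the only guide is that compound 1, built differently on that side, stays at 17400 nM, within the scatter of compound 2. In this assay, the expected change, a 1.3-fold higher number from compound 2 to compound 3 (0.10 log units; within the scatter), is therefore none beyond the scatter. For compound 3 the estimated value is 15000 nM, with an expected range from 6000 nM to 35000 nM.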

Compound 3, half-maximal inhibitory concentration: 7040 nM
Beside the measured number, compound 3's estimate is 2.1-fold (0.33 log units) above it, and the stated range covers the measured number.
By their numbers in this assay, from the lowest: compounds 3, 2 and 1 (each within the scatter of the next, the first and the last beyond it).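

In this assay, swapping 4-butoxyphenyl on a carbonyl carbon for 2-methylphenyl gives a 1.7-fold lower number from compound 2 to compound 3 (0.23 log units; within the scatter) and so shows that this position accepts a group with fewer heavy atoms and no oxygen, with no change that can be told from the scatter. The wider comparison gives a 2.5-fold lower number from compound 1 to compound 3 (0.39 log units; beyond the scatter) for (2-methylphenyl)carbonyl in place of 3-chlorophenyl on an amine nitrogen, the first modest separation among these compounds, showing that a change on this side of the shared core can move the number beyond the scatter. Nothing measured here explains either step.

As far as these compounds go, it remains open whether plain phenyl on the carbonyl carbon would match 2-methylphenyl. From the compounds shown here alone, the effect of a butyl chain, a pyridine ring or a carboxylic acid at this position also remains open.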